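A few compounds are considered here, and "the series" means these few. Any claim that something is new, unique, unknown or untested is made for them only; others in the source may bear on it.

Measured so far:
compound 1 `COc1cc(-c2ccnc3cc(-c4ccc(Cl)cc4)nn23)cc(OC)c1OC` – 2320 nM
compound 2 `COc1ccc(-c2cc3nccc(-c4cc(OC)c(OC)c(OC)c4)n3n2)cc1[N+](=O)[O-]` – > 10000 nM

Compound 1 `COc1cc(-c2ccnc3cc(-c4ccc(Cl)cc4)nn23)cc(OC)c1OC` gives 2320 nM in a functional assay on MCF7 cells (Homo sapiens) for inhibition, read by CCK-8 assay, with a stated time of 48 h (on this read-out lower numbers stand for stronger inhibition and higher numbers for weaker inhibition), and holds the only number shown. Compound 2 `COc1ccc(-c2cc3nccc(-c4cc(OC)c(OC)c(OC)c4)n3n2)cc1[N+](=O)[O-]` reaches only a limit of this assay, > 10000 nM, so no number is known for it (the limit of > 10000 nM in this assay, at which 1 of the 2 values shown sits). Compound 3 `COc1cc(-c2ccnc3cc(-c4ccc(C(C)=O)cc4)nn23)cc(OC)c1OC` is not yet measured; it differs from compound 1 by one change, (acetyl in place of chloro on an aromatic carbon). Among the measured compounds shown here, no measured pair tells how this assay answers such a swap, so compound 3 is expected to stay near compound 1, with a step of a 1.3-fold higher number from compound 1 to compound 3 (0.11 log units; within the scatter) of modest size and uncertain direction. The estimate for compound 3 is 3000 nM, within 1000 nM to 10000 nM.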

Compound 3, half-maximal inhibitory concentration: 5230 nM
Compound 3: middle estimate off by 1.7-fold (0.24 log units), on the low side; measured number inside the range.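

In this assay, this position on the aromatic ring is not indifferent: acetyl in place of chloro gives a 2.3-fold higher number from compound 1 to compound 3 (0.35 log units; beyond the scatter), a modest weakening beyond the scatter. The position still accepts a group of more heavy atoms and keeps a measured number rather than a limit. No measurement shown accounts for this step. From the compounds shown here alone, with a single swap here, it stays open whether an amine, a carboxylic acid or a plain methyl would give a lower or a higher number. Going by these compounds, it also stays open whether the same swap would act alike on another core.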